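Cyclopropylamino in Place of Dimethylamino: An Expected Dose

The compounds below may be only part of what the source reports. "The series", "measured", "known", "first", "only" and "open" are said of these compounds alone.

Compound 1 `CCCn1cnc2c(N(C)C)ncnc21` is the starting point of this account. Among the measured compounds shown here, in a functional assay on the whole organism for antagonist activity, with Rattus norvegicus as the target (on this read-out lower numbers stand for an effect already at smaller amounts and higher numbers for an effect only at larger amounts of compound), compound 1 gives 14 mg/kg, the highest of the three numbers measured so far. Compound 2 `CN(C)c1ncnc2c1ncn2CC1CC1` gives 4.5 mg/kg in this assay, and compound 3 `CN(C)c1ncnc2c1ncn2C1CC1` gives 9 mg/kg. The nearest to compound 1 is compound 3, a 1.6-fold lower number from compound 1 to compound 3 (0.19 log units; within the scatter); the furthest is compound 2, a 3.1-fold lower number from compound 1 to compound 2 (0.49 log units; beyond the scatter). Between the other two, a 2.0-fold higher number from compound 2 to compound 3 (0.30 log units; within the scatter).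

Compound 4 `CCCn1cnc2c(NC3CC3)ncnc21` differs from compound 1 in one place: cyclopropylamino in place of dimethylamino on an aromatic carbon. For the measured compounds named here, none of the measured steps touches this group. Each of them alters only the substituent on the aromatic nitrogen, while the dimethylamino group is kept unchanged in compounds 1, 2 and 3. Going by the values given here, the measured steps therefore give no direct guide to the size or direction of the step from compound 1 to compound 4 in this assay, and the only anchor is the value of compound 1 itself. With nothing in the data pointing one way or the other, no step beyond the scatter is assumed, but the uncertainty is wide.

Compound 4 is accordingly expected to give 14 mg/kg in this assay, with a range from 5 mg/kg to 40 mg/kg. The expected step of no change at the digits printed from compound 1 to compound 4 (within the scatter) would stay within the scatter.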

Compound 4, dose for half-maximal effect: 6 mg/kg
Beside the measured number, compound 4's estimate is 2.3-fold (0.37 log units) above it; measured number inside the range.
By their numbers in this assay, from the lowest: compounds 2, 4, 3 and 1 (each within the scatter of the next, the first and the last beyond it).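

In this assay, the group on the aromatic carbon next to the ring nitrogen proves able to move the number: putting cyclopropylamino in place of dimethylamino gives a 2.3-fold lower number from compound 1 to compound 4 (0.37 log units; beyond the scatter). Among the compounds shown here, compounds 1, 2 and 3 all keep dimethylamino, so they showed only the substituent on the aromatic nitrogen at work, where the one step beyond the scatter is a 3.1-fold lower number from compound 1 to compound 2 (0.49 log units; beyond the scatter); now this second place on the shared core is also seen to respond, by a step beyond the scatter. The change brings in a three-membered ring and a hydrogen-bond donor at once, and no measurement at hand bears on why the number falls or on which of these two differences matters.

A methylamino group or a plain amino group on the same carbon would separate the hydrogen-bond donor from the ring, and a cyclobutylamino group would show whether the size of the ring counts. As far as these compounds go, whether cyclopropylamino gives a similar step with cyclopropylmethyl on the aromatic nitrogen, as in compound 2, also remains open.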